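A few compounds are considered here, and "the series" means these few. Any claim that something is new, unique, unknown or untested is made for them only; others in the source may bear on it.

Measured compounds in a functional assay on EJ cells (Homo sapiens) for antiproliferative activity, read by MTT assay, with a stated time of 24 h; on this read-out higher numbers stand for weaker inhibition and lower numbers for stronger inhibition:
Compound 1 `CCCCNc1nc(-c2ccccc2)c(Cc2c(O)ccc3ccccc23)c(=O)[nH]1` gives 28700 nM.
Compound 2 `CCN(CC)c1nc(-c2ccccc2)c(Cc2c(O)ccc3ccccc23)c(=O)[nH]1` gives 79700 nM.
Compound 3 `O=c1[nH]c(NCCO)nc(-c2ccccc2)c1Cc1c(O)ccc2ccccc12` gives only a limit of the assay, > 300000 nM.

Compound 3 thus stands at the weak end of the three: it reaches no number at all in this assay, only the limit (the limit of > 300000 nM in this assay, at which 1 of the 3 values shown sits), and its steps from compound 1 an at least 10-fold higher number from compound 1 to compound 3 (1.01 log units; beyond the scatter) and from compound 2 an at least 3.7-fold higher number from compound 2 to compound 3 (0.57 log units; beyond the scatter) are both beyond the scatter. The step to compound 4 `COc1ccc(Nc2nc(-c3ccccc3)c(Cc3c(O)ccc4ccccc34)c(=O)[nH]2)cc1` is 4-methoxyphenyl in place of 2-hydroxyethyl on a nitrogen on an aromatic ring. Among the measured compounds shown here, no measured step exchanges an alkyl substituent on that nitrogen for an aromatic one, so the measured steps bear on it only indirectly: the steps of a 2.8-fold higher number from compound 1 to compound 2 (0.44 log units; beyond the scatter) and an at least 10-fold higher number from compound 1 to compound 3 (1.01 log units; beyond the scatter) show that this nitrogen is a place where change moves the number, and that the (2-hydroxyethyl)amino group of compound 3 is the weakest of the three variants tried. Removing the 2-hydroxyethyl group is therefore expected to bring the number back down from the limit, and compound 4 is estimated at 40000 nM, in the range 8000 nM to 200000 nM, which would mean an expected step of an at least 7.5-fold lower number from compound 3 to compound 4 (0.87 log units; beyond the scatter).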

Compound 4, half-maximal inhibitory concentration: 63700 nM
The estimate for compound 4 lay 1.6-fold (0.20 log units) below the measured number, within the range that was stated.
By their numbers in this assay, from the lowest: compound 1; then compounds 4 and 2 (each within the scatter of the next). At a limit, above all of these: compound 3.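

An aromatic substituent on this nitrogen, which compounds 1 to 3 do not carry, still gives a number in this assay, with an at least 4.7-fold lower number from compound 3 to compound 4 (0.67 log units; beyond the scatter), although this comparison rests on a limit for compound 3 and not on a number: the limit of > 300000 nM in this assay, at which 1 of the 4 values shown sits.

The (4-methoxyphenyl)amino group does not match the butylamino group, with a 2.2-fold higher number from compound 1 to compound 4 (0.35 log units; beyond the scatter), and it cannot be told apart from the diethylamino group, with a 1.3-fold lower number from compound 2 to compound 4 (0.10 log units; within the scatter). The 4-methoxyphenyl group is thus accepted on this nitrogen, but it brings no gain over the butyl chain of compound 1.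

On these data alone, it remains open whether an unsubstituted phenyl or a benzyl group on this nitrogen would give a different number from compound 4. As far as these compounds go, it is also open whether a longer alkyl chain, such as hexyl, would give a lower number than compound 1.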